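The compounds below may be only part of what the source reports. "The series", "measured", "known", "first", "only" and "open" are said of these compounds alone.

Measured compounds:
compound 1 `O=C(Nc1cccc(Oc2ccccn2)c1)C1CCCN(C(=O)c2cc(C(F)(F)F)cc(C(F)(F)F)c2)C1`: 0%
compound 2 `O=C(Nc1ccc(Cl)cc1)C1CCCN(C(=O)c2cccc(-c3ccco3)c2)C1`: 0%
compound 3 `Cc1cccc(C(=O)N2CCCC(C(=O)Nc3ccc(Cl)cc3)C2)c1`: 0%

In an ADME assay on PC-3 cells (Homo sapiens) for cytotoxicity, read by WST assay, tested at 100 uM (a lower number here means less inhibition, a higher number more inhibition at the concentration tested (going by the name of the read-out)), compound 1 stands level with compound 2 and compound 3 at the digits reported; nothing in the three values sets it apart. For the measured compounds named here, the one step available, no change at the digits printed from compound 2 to compound 3 (within the scatter), lies inside the scatter, so the series as a whole shows no movement.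

Compound 4 `C=CCOc1cccc(NC(=O)C2CCCN(C(=O)c3cc(C(F)(F)F)cc(C(F)(F)F)c3)C2)c1` differs from compound 1 by allyl in place of pyridin-2-yl on an oxygen on an aromatic ring. Going by the values given here, no measured step touches the oxygen on the aromatic ring; the single step known sits at an aromatic carbon and is flat. With nothing in the data pointing either way, compound 4 is expected to stay where compound 1 stands, and the step expected is no change at the digits printed from compound 1 to compound 4 (within the scatter). For compound 4 the estimate is 0%, with a range from -8% to 12%.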

Compound 4, a percentage reported as inhibition, at one concentration (the size of the read-out at that concentration, not a potency): 0%
Compound 4: the middle estimate sits on the measured number at the digits printed; the range from low to high includes it.
By their numbers in this assay, from the lowest: compounds 1, 2, 3 and 4 (each within the scatter of the next).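

In this assay, for the compounds shown here, allyl in place of pyridin-2-yl on the oxygen gives no change at the digits printed from compound 1 to compound 4 (within the scatter) and so provides the first reading at this place, as the earlier step sat at an aromatic carbon. The aromatic ring on that oxygen is therefore not required for the level seen here, and an open allyl chain reads the same. No supporting data bear on why the read-out stays flat.

With all four compounds level in this assay, nothing yet shows what would move this read-out. From the compounds shown here alone, whether an amine, a carboxylic acid or a longer chain on that oxygen would stay level remains open.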